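Trifluoromethoxy for Trifluoromethyl on Compound 3

The source may hold more compounds than are shown below. What is called first, only, known or untested is meant among the compounds shown, and "the series" means these compounds.

Compounds measured so far in an ADME assay on liver for metabolic stability, with Liver microsome (Rattus norvegicus) as the target, read by LC-MS, using microsomes, with a stated time of 5 h (a higher number here means faster removal of the compound, a lower number slower removal), are these.
Compound 1 `C[C@]1(O)C[C@](c2cccc(OC(F)(F)F)c2)([C@H](O)c2ccccn2)C1` gives 50 mL/min/kg
Compound 2 `O[C@H](c1ccccn1)[C@]1(c2cccc(OC(F)(F)F)c2)C[C@@H](O)C1` gives 217 mL/min/kg
Compound 3 `C[C@]1(O)C[C@@](c2cccc(C(F)(F)F)c2)([C@H](O)c2ccccn2)C1` gives 317 mL/min/kg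

Compound 3 (317 mL/min/kg) stands level with compound 2 within the usual scatter of this assay measurements. Compound 1 is removed more slowly than compound 3, by a margin well beyond that scatter.

The account now turns to compound 4 `C[C@]1(O)C[C@@](c2cccc(OC(F)(F)F)c2)([C@H](O)c2ccccn2)C1` which has not yet been measured. Compared with compound 3, it carries trifluoromethoxy in place of trifluoromethyl on an aromatic carbon of a six-membered aromatic ring of carbon only, meta to a large group (trifluoromethoxy in place of trifluoromethyl on an aromatic carbon).

Going by the values given here, no two measured compounds differ in one place alone, so the data offer no direct measure of this exchange. The two measured compounds that carry trifluoromethoxy give only a loose guide, since compound 1 gives 50 mL/min/kg while compound 2 gives 217 mL/min/kg and these values lie far apart. A modest fall is therefore expected, and the estimated change is a 1.9-fold lower number from compound 3 to compound 4 (0.27 log units; within the scatter) which would lie close to the edge of the scatter. In this assay the estimated value for compound 4 is 170 mL/min/kg with an expected range from 60 mL/min/kg to 400 mL/min/kg around it.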

Compound 4, clearance: 200 mL/min/kg
The estimate for compound 4 lay 1.2-fold (0.07 log units) below the measured number; low and high end bracket the measured number.
By their numbers in this assay, from the lowest: compound 1; then compounds 4, 2 and 3 (each within the scatter of the next).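

In this assay, the exchange of trifluoromethyl for trifluoromethoxy on an aromatic carbon, meta to a large group, can now be read directly, and the step, a 1.6-fold lower number from compound 3 to compound 4 (0.20 log units; within the scatter), shows that this exchange alone leaves the number within the scatter. Methyl in place of hydrogen on a saturated ring carbon behaves the same way, with a 1.1-fold lower number from compound 2 to compound 4 (0.04 log units; within the scatter), so neither of these single changes separates its pair of compounds. The only step beyond the scatter is a 4.0-fold higher number from compound 1 to compound 4 (0.60 log units; beyond the scatter), which means that the low number of compound 1 does not come with the trifluoromethoxy group as such, since compound 4 carries that group too, and the gap between them rests on drawn stereochemistry alone: the fact that compounds 1 and 4 differ only in the configuration as drawn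

The compounds shown leave open whether the configuration of compound 1 would also give slower removal with trifluoromethyl on the aromatic carbon, as the only compound drawn that way carries trifluoromethoxy. They also leave open how a nitrile or a methoxy group on that same aromatic carbon would compare with the two fluorinated groups.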